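Amine substituent change on the shared core

This account rests on a few compounds, and the source may have more. Where it says the series, first, only, none or still open, it means among the compounds named here.

Measured compounds in a functional assay on DU-145 cells (Homo sapiens) for cytotoxicity, read by sulforhodamine B assay, with a stated time of 48 h; on this read-out lower numbers stand for higher toxicity in this test and higher numbers for lower toxicity in this test:
- Compound 1 `CC1CC(C)CN(c2nc(Nc3ccc(C#N)c(C(F)(F)F)c3)nc(Oc3ccnc4ccccc34)n2)C1`: compound 1 reaches only the assay limit, > 100000 nM.
- Compound 2 `N#Cc1ccc(Nc2nc(Oc3ccnc4ccccc34)nc(N3CCN(c4ncccn4)CC3)n2)cc1C(F)(F)F`: compound 2 likewise gives only the limit, > 100000 nM.

Compound 2 thus stands at the limit of this assay, with no number of its own. Going by the values given here, the single measured step, a step that the two limits leave unreadable from compound 1 to compound 2, cannot be sized because both values sit at the limit of > 100000 nM in this assay, at which 2 of the 2 values shown sit.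

Compound 3 `CC(C)N1CCN(c2nc(Nc3ccc(C#N)c(C(F)(F)F)c3)nc(Oc3ccnc4ccccc34)n2)CC1` is the next member. The change from compound 2 is isopropyl in place of pyrimidin-2-yl on an amine nitrogen in a ring. Among the compounds with values here, no measured step bears readably on this change; the only one at hand, a step that the two limits leave unreadable from compound 1 to compound 2, shows that exchanging the whole amine had no visible effect within the tested range. Compound 3 is therefore expected to remain at the limit as well. The expected step that the limit leaves unreadable from compound 2 to compound 3 is estimated as nothing beyond the scatter. Compound 3 is estimated at 150000 nM, with a range from 40000 nM to 600000 nM.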

Compound 3, concentration lethal to 50% of the cells: > 100000 nM
Compound 3: only a limit was reported; the forecaster's own chance of this, stated with the estimate: 80%; the middle value does not contradict the limit.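

No step among compound 1, compound 2 and compound 3 can be read, because each value is only a limit: the limit of > 100000 nM in this assay, at which 3 of the 3 values shown sit.

The compounds shown leave open whether any amine substituent on the shared core gives a measurable value in this assay, and how these three substituents rank.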